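This account rests on a few compounds, and the source may have more. Where it says the series, first, only, none or still open, it means among the compounds named here.

Measured so far:
- compound 1 `CC(C)c1nc2ccccn2c1C(=O)NCc1ccc(-c2ccccc2)cc1` gives 0.527 h here
- compound 2 `CCc1nc2cc(Cl)ccn2c1C(=O)NCc1ccc(-c2ccc(C)cc2)cc1` gives 0.423 h here

In an ADME assay (liver) for metabolic stability, with Liver microsome (Homo sapiens) as the target, using microsomes (on this read-out lower numbers stand for a shorter-lived compound and higher numbers for a longer-lived compound), compound 2 stands at 0.423 h within the usual scatter of compound 1 at 0.527 h so the two cannot be told apart, even though their structures differ in more than one place.

The next compound to be measured is compound 3 `CCc1nc2cc(Cl)ccn2c1C(=O)NCc1ccc(-c2ccc(Cl)cc2)cc1` and it differs from compound 2 in one place only. That change is chloro in place of methyl on an aromatic carbon and it amounts to chloro in place of methyl on an aromatic carbon, para to a large group, so 4-methylphenyl becomes 4-chlorophenyl.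

Within the data shown here, no measured pair shows this swap, so any forecast is loose. A modest rise is expected, with the estimated step of a 1.3-fold higher number from compound 2 to compound 3 (0.11 log units; within the scatter) probably staying within the scatter. The estimated half-life of compound 3 is 0.55 h with an expected range from 0.28 h to 1.1 h in this assay once it is measured.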

Compound 3, half-life: > 2 h
Compound 3 gave a limit, no number; the forecaster's own chance of this, stated with the estimate: 3%; middle value at least 3.6-fold (0.56 log units) from the limit.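

In this assay, replacing 4-methylphenyl with 4-chlorophenyl, a change of one atom on an aromatic carbon para to a large group, gives an at least 4.7-fold higher number from compound 2 to compound 3 (0.67 log units; beyond the scatter), so this single position has a clear hold on half-life. Compounds 1 and 2 could not be told apart and differed in more than one place, which makes this the first change whose effect can be read on its own. Compound 3 gave a limit of the assay and not a number, so the full size of the step stays unknown: the limit of > 2 h in this assay, at which 1 of the 3 values shown sits.

The compounds shown leave open whether a fluoro, a methoxy or a carboxylic acid at this position would behave like chloro. They also do not tell whether the same swap would give a similar step on a different core, or why it has this effect.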